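Cytotoxicity notes: amino to nitro on the benzyl arm

The source may report more compounds than this note shows. Statements on the series, on what has been measured and on what is new or still open speak of the compounds shown alone.

Measured so far:
compound 1, `COC(=O)c1ccc(NCc2cncn2Cc2ccccc2N)cc1-c1ccccc1`: 25000 nM
compound 2, `Cc1cccc(-c2cccc(NCc3cncn3Cc3ccccc3)c2)c1`: > 1000 nM

Within the data shown here, in a toxicity assay on NIH3T3 cells (Mus musculus) for cytotoxicity, read by resazurin assay (on this read-out higher numbers stand for an effect only at larger amounts of compound and lower numbers for an effect already at smaller amounts), compound 1 gives 25000 nM, the only plain number in the set so far. For compound 2 the read-out > 1000 nM is a limit of this assay, not a number. Compound 3, `COC(=O)c1ccc(NCc2cncn2Cc2ccccc2[N+](=O)[O-])cc1-c1ccccc1`, is not yet measured. It differs from compound 1 by nitro in place of amino on an aromatic carbon. Among the measured compounds shown here, no measured pair shows the effect of this change, so no step beyond the usual scatter is expected in this assay, in either direction. For compound 3 the estimate is 25000 nM, between 8000 nM and 80000 nM, an expected step of no change at the digits printed from compound 1 to compound 3 (within the scatter).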

Compound 3, half-maximal effective concentration: 10000 nM
The estimate for compound 3 lay 2.5-fold (0.40 log units) above the measured number, within the range that was stated.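

In this assay, among these compounds, the first readable step at this position is a 2.5-fold lower number from compound 1 to compound 3 (0.40 log units; beyond the scatter), with nitro in place of amino on an aromatic carbon ortho to a large group. The position therefore responds to this change, though only modestly, and the nitro compound acts at smaller amounts. Nothing available bears on why this step arises. From the compounds shown here alone, whether a methoxy group, an acetamide or a carboxylic acid at this place would read closer to compound 1 or compound 3 stays open. One pair also leaves open whether the step carries over to other cores.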